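Amide to sulfonamide exchange at the anilide nitrogen

The source may hold more compounds than are shown below. What is called first, only, known or untested is meant among the compounds shown, and "the series" means these compounds.

Compound 1 `COc1cccc(C(=O)Nc2cccc(/C=C/C(=O)c3nc4ccccc4[nH]3)c2)c1` gives 3680 nM in a functional assay on HCT-116 cells (Homo sapiens) for antiproliferative activity, read by MTT assay, with a stated time of 48 h; on this read-out higher numbers stand for weaker inhibition and lower numbers for stronger inhibition.
Compound 2 `Cc1cc(C)cc(C(=O)Nc2cccc(/C=C/C(=O)c3nc4ccccc4[nH]3)c2)c1` gives 1550 nM in this assay.

Compound 2 holds the lower of the two numbers, compound 1 being the nearest by a 2.4-fold lower number from compound 1 to compound 2 (0.38 log units; beyond the scatter). Compound 3 `O=C(/C=C/c1cccc(NS(=O)(=O)c2cccc(Cl)c2)c1)c1nc2ccccc2[nH]1` differs from compound 2 by (3-chlorophenyl)sulfonyl in place of (3,5-dimethylphenyl)carbonyl on a nitrogen on an aromatic ring. Among the measured compounds shown here, the single measured step, a 2.4-fold lower number from compound 1 to compound 2 (0.38 log units; beyond the scatter), only exchanges the aryl group on the carbonyl; no measured step covers exchanging the carbonyl itself for a sulfonyl, so it gives little guidance. Only a small step is expected, a 1.3-fold higher number from compound 2 to compound 3 (0.11 log units; within the scatter), in no firm direction. Compound 3 is estimated at 2000 nM, with a range of 700 nM to 6000 nM.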

Compound 3, half-maximal inhibitory concentration: 737 nM
Beside the measured number, compound 3's estimate is 2.7-fold (0.43 log units) above it, and the stated range covers the measured number.
By their numbers in this assay, from the lowest: compound 3; then compound 2; then compound 1.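

On the nitrogen on an aromatic ring, the carbonyl is not required: (3-chlorophenyl)sulfonyl is accepted in its place, with a 2.1-fold lower number from compound 2 to compound 3 (0.32 log units; beyond the scatter) and a 5.0-fold lower number from compound 1 to compound 3 (0.70 log units; beyond the scatter) in this exchange. Each step changes the linking group and the aryl substituents together, so neither change can be credited alone. Nothing available bears on the origin of these steps. Still open, from the compounds shown here alone, is whether (3-chlorophenyl)carbonyl or (3,5-dimethylphenyl)sulfonyl would separate the two changes. Also open, going by these compounds, is how a methylsulfonyl group, with no aryl ring, would behave on this nitrogen.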